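The source may hold more compounds than are shown below. What is called first, only, known or untested is meant among the compounds shown, and "the series" means these compounds.

The shared core of these compounds is seen in compound 1 `O=C(Cc1cccnc1)c1cc2cc(F)ccc2[nH]1`. Going by the values given here, in an assay on isolated protein for inhibition of Indoleamine 2,3-dioxygenase 1 (Homo sapiens), read by spectrophotometry (a lower number here means a stronger inhibitor, a higher number a weaker inhibitor), compound 1 gives 36000 nM, and this is the only number among the three measured compounds. Compound 2 `O=C(Cc1ccncc1)c1cc2ccccc2[nH]1` is reported in this assay as "not active" (no number reported). Compound 3 `COc1ccc2[nH]c(C(=O)Cc3cccnc3)cc2c1OCc1ccccc1` is reported in this assay as "not active" (no number reported). Compound 4 `O=C(Cc1cccnc1)c1cc2cc([N+](=O)[O-])ccc2[nH]1` has not yet been tested; it differs from compound 1 by nitro in place of fluoro on an aromatic carbon. Among the compounds with values here, no two measured compounds differ in just one place, so there is no measured step to lean on. The step that the estimate below means, a 1.4-fold lower number from compound 1 to compound 4 (0.16 log units; within the scatter), is expected to be small, likely within the usual scatter, with either direction possible. Compound 4 is estimated at 25000 nM, with a range from 6000 nM to 100000 nM.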

Compound 4, half-maximal inhibitory concentration: "not active" (no number reported)
For compound 4 the study gives words and no number, and the estimate cannot be compared.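

Going by these compounds alone, compound 4 is reported in words without a number, and no step from compound 1 to compound 4 can be read. No measured evidence bears on this result. In this assay the compounds shown leave open what nitro in place of fluoro does to the number.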